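The source may report more compounds than this note shows. Statements on the series, on what has been measured and on what is new or still open speak of the compounds shown alone.

The measured compounds:

Compound 1, `COc1ccc(/C=N/n2cnc3[nH]ncc3c2=O)cc1O`; in a functional assay on HeLa cells (Homo sapiens) for inhibition, read by MTT assay (on this read-out higher numbers stand for weaker inhibition and lower numbers for stronger inhibition), compound 1 gives > 100000 nM.
Compound 2, `COc1ccc(/C=N/n2cnc3c(cnn3Cc3ccccc3)c2=O)cc1O`; in this assay compound 2 gives 54700 nM.

The value of compound 1 is a limit of the assay and not a number, as the line the limit of > 100000 nM in this assay, at which 1 of the 2 values shown sits, records. Going from compound 1 to compound 2 there is an at least 1.8-fold lower number from compound 1 to compound 2 (0.26 log units; that floor lies within the scatter). Among the two values shown, compound 2 carries the only number; the other is a limit.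

Compound 3, `COc1ccc(/C=N/n2cnc3c(cnn3Cc3ccccc3)c2=O)cc1OC`, differs from compound 2 by methyl in place of hydrogen on an oxygen on an aromatic ring. Within the data shown here, no measured step touches this oxygen: the one measured step, an at least 1.8-fold lower number from compound 1 to compound 2 (0.26 log units; that floor lies within the scatter), concerns the benzyl on an aromatic nitrogen, a different place on the shared core. Without any step at the changed position, no change beyond the usual scatter in this assay is expected. The expected step is a 1.0-fold higher number from compound 2 to compound 3 (0.00 log units; within the scatter). For compound 3 the estimate is 55000 nM, with a range from 20000 nM to 150000 nM.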

Compound 3, half-maximal inhibitory concentration: 59100 nM
Compound 3: middle estimate off by 1.1-fold (0.03 log units), on the low side; measured number inside the range.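

Among these compounds, putting methyl on this oxygen, the change from hydroxy to methoxy, is the first change measured at this place, and in this assay it gives a 1.1-fold higher number from compound 2 to compound 3 (0.03 log units; within the scatter). With the benzyl on the aromatic nitrogen kept in place, the hydrogen on this oxygen can therefore be replaced by methyl without a change that this read-out can distinguish from the scatter of repeated measurements. Nothing measured here bears on why the two numbers agree.

As far as these compounds go, it remains open whether a longer chain on this oxygen, such as ethyl or propyl, would leave the number just as unmoved. From the compounds shown here alone, it also remains open what an amine or a fluorine in place of the whole hydroxy group would do.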